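The source may report more compounds than this note shows. Statements on the series, on what has been measured and on what is new or still open speak of the compounds shown alone.

Measured so far in a functional assay on HT-29 cells (Homo sapiens) for cytotoxicity, read by MTT assay, with a stated time of 72 h; a higher number here means that more compound is tolerated, a lower number that less compound is tolerated:
compound 1 `COc1ccc(OC(=O)Nc2ccc([Se]C#N)cc2)cc1` — 69600 nM
compound 2 `N#C[Se]c1ccc(NC(=O)Oc2ccc(F)cc2)cc1` — 66500 nM

In this assay compound 2 gives the lower of the two numbers, but the gap to compound 1 is small: a 1.0-fold lower number from compound 1 to compound 2 (0.02 log units; within the scatter). Compound 3 `Cc1ccc(OC(=O)Nc2ccc([Se]C#N)cc2)cc1` differs from compound 2 by methyl in place of fluoro on an aromatic carbon. For the measured compounds named here, the only step bearing on this, the exchange of the substituent para to a large group from compound 1 to compound 2, stayed within the scatter, so no step beyond the scatter is expected here either. Compound 3 is estimated at 68000 nM, range 35000 nM to 130000 nM, meaning an expected 1.0-fold higher number from compound 2 to compound 3 (0.01 log units; within the scatter).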

Compound 3, concentration lethal to 50% of the cells: 68700 nM
Compound 3: the middle estimate sits 1.0-fold (0.00 log units) below what was measured, and the stated range covers the measured number.
By their numbers in this assay, from the lowest: compounds 2, 3 and 1 (each within the scatter of the next).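

In this assay methyl joins fluoro and methoxy on the aromatic carbon para to a large group, and both new steps stay within the scatter (a 1.0-fold higher number from compound 2 to compound 3 (0.01 log units; within the scatter)) and (a 1.0-fold lower number from compound 1 to compound 3 (0.01 log units; within the scatter)). The first exchange is therefore no longer a lone case: all three substituents at this position give numbers within the scatter of each other. No measurement among the data given explains this flat response.

Open, going by these compounds, is whether an amine or a carboxylic acid here would move the number beyond the scatter. The rest of the shared core stays unchanged, so its part remains unread.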